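Nucleoside-triazole conjugates: removal of a chain methyl

A few compounds are considered here, and "the series" means these few. Any claim that something is new, unique, unknown or untested is made for them only; others in the source may bear on it.

Within the data shown here, compound 2 `CCn1c(=O)ccn(C2OC(Cn3cc(COC(=O)C(C)n4cnc5c4c(=O)n(C)c(=O)n5C)nn3)C(O)C2O)c1=O` gives 2890 nM in a functional assay on A549 cells (Homo sapiens) for cytotoxicity, read by MTT assay, with a stated time of 48 h (a higher number here means a weaker inhibitor, a lower number a stronger inhibitor), the lower of the two numbers known so far. Compound 1 `C#CCNC(=O)Cn1cnc2c1c(=O)n(C)c(=O)n2C` gives 114000 nM in this assay, a far higher value. Compound 3 `CCn1c(=O)ccn(C2OC(Cn3cc(COC(=O)Cn4cnc5c4c(=O)n(C)c(=O)n5C)nn3)C(O)C2O)c1=O` differs from compound 2 by hydrogen in place of methyl on a saturated chain carbon bound to an aromatic nitrogen and a carbonyl carbon. Among the measured compounds shown here, no step between measured compounds isolates such a change; the shared core and the remainder of compound 2 are kept, so the step is expected to be small, within the scatter, with no clear direction. Compound 3 is therefore expected to give 3500 nM in this assay, between 1200 nM and 10000 nM. The expected step of a 1.2-fold higher number from compound 2 to compound 3 (0.08 log units; within the scatter) thus means little change.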

Compound 3, half-maximal inhibitory concentration: 2560 nM
Compound 3: the middle estimate sits 1.4-fold (0.14 log units) above what was measured; measured number inside the range.
By their numbers in this assay, from the lowest: compounds 3 and 2 (each within the scatter of the next); then compound 1.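

In this assay, hydrogen in place of methyl on the saturated chain carbon bound to an aromatic nitrogen and a carbonyl carbon gives a 1.1-fold lower number from compound 2 to compound 3 (0.05 log units; within the scatter). Among these compounds, this is the first step to isolate this position, and the methyl can be replaced by hydrogen with no change beyond the scatter. No data on the origin of this result are available.

On these data alone, whether a longer chain such as ethyl, an amine or a carboxylic acid at this carbon would shift the number in this assay remains open. This single pair also leaves open whether the same change behaves alike with other groups elsewhere on the compound.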